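A few compounds are considered here, and "the series" means these few. Any claim that something is new, unique, unknown or untested is made for them only; others in the source may bear on it.

Measured so far:
compound 1 `Nc1nc(N/N=C/c2ccc(OCc3ccc(F)cc3)cc2)nc2c1ncn2[C@@H]1O[C@H](CO)[C@@H](O)[C@H]1O` — 70 nM
compound 2 `COc1ccc(/C=N/Nc2nc(N)c3ncn([C@@H]4O[C@H](CO)[C@@H](O)[C@H]4O)c3n2)cn1` — 2.6 nM

In an assay on CHO-K1 cells for displacement of a labelled ligand from adenosine receptor A1 (Homo sapiens), read by scintillation counting, with a stated time of 60 min (a lower number here means a stronger inhibitor, a higher number a weaker inhibitor), compound 2 gives the lowest of the two numbers shown, and compound 1, the only neighbour, sits well beyond the usual scatter above it. Compound 3 `Nc1nc(N/N=C/c2ccc(N3CCCC3)cc2)nc2c1ncn2[C@@H]1O[C@H](CO)[C@@H](O)[C@H]1O` has not yet been measured in this assay. It differs from compound 2 in one place: 4-(pyrrolidin-1-yl)phenyl in place of 6-methoxypyridin-3-yl on a carbon with a double bond to nitrogen. Among the measured compounds shown here, no step between two measured compounds covers this kind of change, so any expectation rests only on the two values in hand. The step of a 5.8-fold higher number from compound 2 to compound 3 (0.76 log units; beyond the scatter) is expected to raise the number, with compound 3 estimated at 15 nM, likely between 3 nM and 80 nM.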

Compound 3, inhibition constant: 5.1 nM
Compound 3: the middle estimate sits 2.9-fold (0.47 log units) above what was measured, within the range that was stated.
By their numbers in this assay, from the lowest: compounds 2 and 3 (each within the scatter of the next); then compound 1.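

In this assay, replacing 6-methoxypyridin-3-yl with 4-(pyrrolidin-1-yl)phenyl on this carbon gives a 2.0-fold higher number from compound 2 to compound 3 (0.29 log units; within the scatter), so these two quite different groups cannot be told apart here. Replacing (4-fluorobenzyl)oxy with pyrrolidin-1-yl on the aromatic carbon gives a 14-fold lower number from compound 1 to compound 3 (1.14 log units; beyond the scatter), which shows that the group at that place can change the number strongly. Nothing available explains either result.

Going by these compounds, it remains open whether a dimethylamino group or a piperidine ring on that aromatic carbon would match pyrrolidin-1-yl. On these data alone, whether a shorter benzyloxy group without fluorine would behave like (4-fluorobenzyl)oxy also remains open.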